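The source may report more compounds than this note shows. Statements on the series, on what has been measured and on what is new or still open speak of the compounds shown alone.

Compound 1 `COc1cc2c(cc1O)CCC(C)(CC(=O)N[C@@H](C)C(=O)O)O2`: 100%
Compound 2 `COc1cc2c(cc1O)CCC(C)(CC(=O)N[C@H](C(=O)O)C(C)C)O2`: 82.6%
Compound 3 `COc1cc2c(cc1O)CCC(C)(CC(N)=O)O2`: 100%

In an ADME assay on SH-SY5Y cells (Homo sapiens) for cytotoxicity, read by MTT assay, with a stated time of 24 h, tested at 12.5 uM (a lower number here means a stronger effect, a higher number a weaker effect of the compound at the concentration tested), compound 3 stands level with compound 1, the two together giving the highest of the three numbers; the only gap beyond the scatter is a number 17.4 percentage points higher from compound 2 to compound 3 (beyond the scatter). Compound 4 `COc1cc2c(cc1O)CCC(C)(CC(N)C(=O)O)O2` differs from compound 3 by amino(carboxy)methyl in place of carbamoyl on a saturated chain carbon bound to a saturated ring carbon. Among the compounds with values here, no measured step touches this place on the shared core. The nearest guides are the changes at the amide nitrogen, no change at the digits printed from compound 1 to compound 3 (within the scatter) and a number 17.4 percentage points higher from compound 2 to compound 3 (beyond the scatter), which show that adding or removing a carboxy-bearing chain shifts this read-out little, at most modestly. A small step in this assay is therefore expected, a number 6 percentage points lower from compound 3 to compound 4 (within the scatter), with any change most likely downward. Compound 4 is estimated to give 94%, within 75% to 100%.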

Compound 4, a percentage reported as activity, at one concentration (the size of the read-out at that concentration, not a potency): 100%
Beside the measured number, compound 4's estimate is 6 percentage points below it; measured number inside the range.
By their numbers in this assay, from the lowest: compound 2; then compounds 1, 3 and 4 (each within the scatter of the next).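

In this assay, exchanging the carbamoyl group for amino(carboxy)methyl gives no change at the digits printed from compound 3 to compound 4 (within the scatter). Within the data shown here, this is the first measured change at this place on the shared core, and it shows that the larger group leaves the read-out where it was. Nothing measured here explains this result. Still open, as far as these compounds go, is whether a simple amine or a carboxylic acid alone at this place would behave the same way. A longer chain carrying these groups also remains untested among the compounds shown.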